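Solubility notes: cyclopropyl for methyl on the shared core

This account rests on a few compounds, and the source may have more. Where it says the series, first, only, none or still open, it means among the compounds named here.

Going by the values given here, compound 2 `Cc1nc2c(C#N)c(C)c(-c3ccccc3)c(N3CC[C@H](N(C)C)C3)n2n1` is the only compound here with a number in a physicochemical assay for solubility, at pH 6.8; a lower number here means a less soluble compound, a higher number a more soluble compound: compound 2 gives 376 ug/mL. Compound 1 `Cc1c(-c2ccccc2)c(N2CC[C@H](N(C)C)C2)n2nc(C(C)(C)COCc3ccccc3)nc2c1C#N` gives only a limit of the assay, < 3 ug/mL. Among the compounds with values here, the single measured step, an at least 120-fold higher number from compound 1 to compound 2 (2.09 log units; beyond the scatter), is large and upward, starting from the limit of < 3 ug/mL in this assay, at which 1 of the 2 values shown sits. Compound 3 `Cc1c(-c2ccccc2)c(N2CC[C@H](N(C)C)C2)n2nc(C3CC3)nc2c1C#N` differs from compound 2 by cyclopropyl in place of methyl on an aromatic carbon. Set against the measured step, this change is far smaller, and only a modest lowering is expected: a 2.5-fold lower number from compound 2 to compound 3 (0.40 log units; beyond the scatter). For compound 3 the expected value in this assay is 150 ug/mL, with a range from 40 ug/mL to 400 ug/mL.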

Compound 3, solubility: 57 ug/mL
Estimate against measurement, compound 3: 2.6-fold (0.42 log units) above; measured number inside the range.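

At this aromatic carbon, even the small change from methyl to cyclopropyl registers in this assay, with a 6.6-fold lower number from compound 2 to compound 3 (0.82 log units; beyond the scatter). Cyclopropyl still stands well clear of 1-((benzyloxy)methyl)-1-methylethyl, with an at least 19-fold higher number from compound 1 to compound 3 (1.27 log units; beyond the scatter). That second step is only a bound, as compound 1 gives a limit and not a number: the limit of < 3 ug/mL in this assay, at which 1 of the 3 values shown sits.

Only these three groups are shown on this carbon, so no general trend can be drawn from them. Going by these compounds, how an amine or a carboxylic acid at this position would read in this assay remains open.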